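Replacing Fluoro with Phenoxy on an Aromatic Carbon

A few compounds are considered here, and "the series" means these few. Any claim that something is new, unique, unknown or untested is made for them only; others in the source may bear on it.

In a functional assay on HeLa cells (Homo sapiens) for inhibition, read by CCK-8 assay, with a stated time of 72 h (a higher number here means a weaker inhibitor, a lower number a stronger inhibitor), compound 1 `O=C(/C=C/c1cccnc1)NCCCCCCc1cccc(S(=O)(=O)Nc2ccccc2)c1` gives 30.4 nM, and compound 2 `O=C(/C=C/c1cccnc1)NCCCCCCc1cccc(S(=O)(=O)Nc2ccc(F)cc2)c1` gives 99.9 nM, the higher and therefore weaker of the two numbers. Compound 3 `O=C(/C=C/c1cccnc1)NCCCCCCc1cccc(S(=O)(=O)Nc2ccc(Oc3ccccc3)cc2)c1` keeps the shared core but exchanges the fluoro of compound 2 for phenoxy: phenoxy in place of fluoro on an aromatic carbon. The new group stands on an aromatic carbon, para to a large group. Among the measured compounds shown here, only one measured step bears on this change: a 3.3-fold higher number from compound 1 to compound 2 (0.52 log units; beyond the scatter), a modest step that came with fluoro in place of hydrogen at that carbon. For the measured compounds named here, no measured compound carries a group as large as phenoxy there, so the guidance is thin. Going by a 3.3-fold higher number from compound 1 to compound 2 (0.52 log units; beyond the scatter), a further modest rise is expected in this assay, although a fall remains possible. The expected change is a 1.5-fold higher number from compound 2 to compound 3 (0.18 log units; within the scatter). For compound 3, the estimated value is 150 nM, with an expected range of 30 nM to 700 nM.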

Compound 3, half-maximal inhibitory concentration: 262 nM
Compound 3: the middle estimate sits 1.7-fold (0.24 log units) below what was measured; measured number inside the range.
By their numbers in this assay, from the lowest: compound 1; then compound 2; then compound 3.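

In this assay, among the compounds shown here, exchanging fluoro for phenoxy on this aromatic carbon brings a 2.6-fold higher number from compound 2 to compound 3 (0.42 log units; beyond the scatter), so across these three compounds the number rises as the group grows from hydrogen through fluoro to phenoxy, with no compound going against that order. Measured against plain hydrogen, phenoxy gives an 8.6-fold higher number from compound 1 to compound 3 (0.94 log units; beyond the scatter), which leaves compound 1 as the strongest of the three, while a whole extra aromatic ring at this carbon still leaves compound 3 with a measurable inhibitory value. Nothing available explains why the number rises along this series.

Three groups cannot show whether size alone tracks the rise, since fluoro and phenoxy differ in more than size. A methyl, a methoxy, an amine or a carboxylic acid on this same carbon would test how far the order holds.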